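The compounds below may be only part of what the source reports. "The series", "measured", "known", "first", "only" and "open" are said of these compounds alone.

Working notes on the series. Compound 2, `N#Cc1c2n(c(=O)n(-c3ccccc3)/c1=N\CCO)CCC2`, in a functional assay on the whole organism (strain albino) for inhibition, with Rattus norvegicus as the target, read by paw edema, with a stated time of 3 h, at a dose of 0.029 mmol/kg by the oral route (on this read-out lower numbers stand for less inhibition and higher numbers for more inhibition at the one dose given (going by the name of the read-out)), gives 25.9%. Compound 1, `C/N=c1/c(C#N)c2n(c(=O)n1-c1ccccc1)CCC2`, in this assay gives 30.2%. Going by the values given here, on the two numbers in hand compound 2 stands lowest, with compound 1 as its nearest neighbour; the single step in hand, a number 4.3 percentage points lower from compound 1 to compound 2 (within the scatter), is the only measured comparison and it does not separate the two compounds beyond the scatter.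

Compound 3, `CCCC/N=c1/c(C#N)c2n(c(=O)n1-c1ccccc1)CCC2`, has not yet been measured. Compared with compound 2 the difference is ethyl in place of hydroxy on a saturated chain carbon, two bonds along the chain from a double-bonded nitrogen. Among the compounds with values here, no measured step touches this exact change; the one step in hand concerns a different part of the same chain and was within the scatter, so there is no basis for expecting a step beyond the scatter in this assay in either direction.

Compound 3 is therefore expected to give about 29% in this assay, with a range of 14% to 44%. The expected step is a number 3.1 percentage points higher from compound 2 to compound 3 (within the scatter). This estimate rests on the two measured numbers alone: compound 2 gives 25.9%. Compound 1 gives 30.2%.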

Compound 3, a percentage reported as inhibition, in the whole organism at one dose (the size of the read-out at that dose, not a potency): 19.4%
Compound 3: the middle estimate sits 9.6 percentage points above what was measured, within the range that was stated.
By their numbers in this assay, from the lowest: compounds 3, 2 and 1 (each within the scatter of the next, the first and the last beyond it).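

In this assay, ethyl in place of hydroxy on a saturated chain carbon, two bonds along the chain from a double-bonded nitrogen, gives a number 6.5 percentage points lower from compound 2 to compound 3 (within the scatter) and so does not separate the 2-hydroxyethyl chain from the butyl chain at this dose. Propyl in place of hydrogen on a saturated chain carbon bound to a double-bonded nitrogen gives a number 10.8 percentage points lower from compound 1 to compound 3 (beyond the scatter) and is the only step so far to pass the scatter, a modest one, so the methyl and butyl ends of this short set can be told apart while compound 2 cannot be placed apart from either. Nothing at hand explains either step.

The compounds shown leave open how a chain longer than butyl, such as hexyl, would read in this assay and whether the step from compound 1 grows or fades with it. They also leave open how an amine or a carboxylic acid in place of the hydroxy of compound 2 would read at this same dose.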